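Furan-pyridine series: topoisomerase inhibition notes

A few compounds are considered here, and "the series" means these few. Any claim that something is new, unique, unknown or untested is made for them only; others in the source may bear on it.

Measured so far:
compound 1 `Clc1ccc(-c2cc(-c3cccnc3)nc(-c3ccsc3)c2)o1` — 0%
compound 2 `Clc1ccc(-c2cc(-c3cccnc3)nc(-c3cccs3)c2)o1` — 25.8%

In an assay on isolated protein for inhibition of DNA topoisomerase 1 (Homo sapiens), tested at 100 uM (on this read-out lower numbers stand for a weaker effect and higher numbers for a stronger effect at the one concentration tested), compound 1 gives 0%, the lower of the two numbers; the nearest is compound 2, whose value sits higher by a number 25.8 percentage points higher from compound 1 to compound 2 (beyond the scatter).

Compound 3 `Clc1ccc(-c2cc(-c3ccsc3)nc(-c3ccccn3)c2)o1` is the unmeasured member. Relative to compound 1 it differs as follows: pyridin-2-yl in place of pyridin-3-yl on an aromatic carbon.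

Among the compounds with values here, no measured step covers an exchange of one pyridinyl for another on this core. Within the data shown here, the only step in hand, a number 25.8 percentage points higher from compound 1 to compound 2 (beyond the scatter), concerns an exchange of thiophenyl isomers elsewhere on the same core and shows that moving an attachment point can shift the read-out modestly in this assay. Among the measured compounds shown here, by that loose analogy, and with no direct precedent, compound 3 is expected to come out near compound 1, with a step of a number 10 percentage points higher from compound 1 to compound 3 (within the scatter) at most. The estimate for compound 3 in this assay is therefore 10%, within 0% to 35%.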

Compound 3, a percentage reported as inhibition, at one concentration (the size of the read-out at that concentration, not a potency): 0%
Compound 3: middle estimate off by 10 percentage points, on the high side; the range from low to high includes it.
By their numbers in this assay, from the lowest: compounds 1 and 3 (each within the scatter of the next); then compound 2.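

Within the data shown here, at the position meta to the 5-chlorofuran-2-yl and thiophen-3-yl groups, the first pyridinyl isomer exchange in this assay gives no change at the digits printed from compound 1 to compound 3 (within the scatter). Unlike the thiophenyl exchange, a number 25.8 percentage points higher from compound 1 to compound 2 (beyond the scatter), this exchange of attachment point separates nothing on this read-out, although both compounds sit at the bottom of the numbers seen so far, where a further loss could not show. No supporting data bear on why the two pyridinyl isomers read alike.

Still open, as far as these compounds go, is whether the same pyridinyl exchange would register when paired with thiophen-2-yl, the group present in compound 2, where the read-out has room to fall. Also open, from the compounds shown here alone, is how this assay responds at this position to a non-aromatic replacement, such as a carboxylic acid or an aminomethyl group.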